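Anilino Quinone Series: Step from Compound 2 to Compound 4

A few compounds are considered here, and "the series" means these few. Any claim that something is new, unique, unknown or untested is made for them only; others in the source may bear on it.

Measured so far:
compound 1 `O=C1C=CC(=O)c2ncncc21`, 9400 nM
compound 2 `O=C1C(Nc2ccc(Oc3ccccc3)cc2)=CC(=O)c2ncncc21`, 3700 nM
compound 3 `COc1cccc(NC2=CC(=O)c3ncncc3C2=O)c1`, 1800 nM

In a functional assay on MIA PaCa-2 cells (Homo sapiens) for cytotoxicity, read by MTT assay, with a stated time of 72 h (on this read-out lower numbers stand for stronger inhibition and higher numbers for weaker inhibition), compound 1 gives 9400 nM, the highest number of the three. Compound 2 stands second highest with 3700 nM; its nearest neighbour is compound 3 at 1800 nM, a gap beyond the scatter, and its furthest is compound 1, also beyond the scatter. Both anilino compounds thus give lower numbers than the bare core of compound 1.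

Compound 4 `COc1ccc(NC2=CC(=O)c3ncncc3C2=O)cc1` is not yet measured. It differs from compound 2 in one place:

methyl in place of phenyl on an oxygen on an aromatic ring

Among the measured compounds shown here, no measured pair shows this change directly. Compound 3 carries a methoxy on its anilino ring and gives 1800 nM, a lower number than compound 2, so a modest move to a lower number is expected, likely not clearly beyond the scatter. The step from compound 2 to compound 4 is estimated at a 1.5-fold lower number from compound 2 to compound 4 (0.17 log units; within the scatter). Compound 4 is expected to give about 2500 nM, within 1000 nM to 6000 nM.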

Compound 4, half-maximal inhibitory concentration: 1900 nM
The estimate for compound 4 lay 1.3-fold (0.12 log units) above the measured number, and the stated range covers the measured number.
By their numbers in this assay, from the lowest: compounds 3, 4 and 2 (each within the scatter of the next, the first and the last beyond it); then compound 1.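

In this assay the change from phenoxy to methoxy, methyl in place of phenyl on an oxygen on an aromatic ring, reads as a 1.9-fold lower number from compound 2 to compound 4 (0.29 log units; within the scatter) and stays within the scatter. Among the compounds shown here, this is the first direct reading of this change, and compound 2 and compound 4 cannot be told apart here. On this oxygen, then, the aromatic phenyl ring is not needed to hold the value, and the much smaller methyl serves as well. The data at hand offer nothing that accounts for this result.

Phenyl and methyl are the only groups shown on this oxygen, so the reading covers just these two. Going by these compounds, whether a hydrogen, a benzyl group or a longer chain such as butyl would stay within the scatter of compound 4 remains open.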